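Shortening the chain once more: from compound 3 to compound 4

The compounds below may be only part of what the source reports. "The series", "measured", "known", "first", "only" and "open" are said of these compounds alone.

Compound 1, `CCCCC/C=C/CCCCCCCCCC1(C(=O)OC)CO1`: 5 uM in a functional assay for inhibition, with Rattus norvegicus as the target; a lower number here means that less compound is needed, a higher number that more compound is needed for the effect
Compound 2, `CCCCCCCCCCCCCCC1(C(=O)OC)CO1`: 0.1 uM
Compound 3, `CCCCCCCCCCCCC1(C(=O)OC)CO1`: 1 uM

Compound 3 stands second highest of the three numbers. Two steps lead to it: a 5.0-fold lower number from compound 1 to compound 3 (0.70 log units; beyond the scatter) and a 10-fold higher number from compound 2 to compound 3 (1.00 log units; beyond the scatter). Compound 4, `CCCCCCCCCCC1(C(=O)OC)CO1`, differs from compound 3 by hydrogen in place of ethyl on a saturated chain carbon, ten or more bonds along the chain from a saturated ring carbon. Among the measured compounds shown here, only one measured step bears on this change, a 10-fold higher number from compound 2 to compound 3 (1.00 log units; beyond the scatter), which is the same shortening taken one stage earlier, and it was beyond the scatter. A step of similar kind is therefore expected here, a 5.0-fold higher number from compound 3 to compound 4 (0.70 log units; beyond the scatter), giving a higher number. Compound 4 is estimated at 5 uM, with a range from 1.5 uM to 20 uM.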

Compound 4, minimum effective concentration: 0.5 uM
Estimate against measurement, compound 4: 10-fold (1.00 log units) above, and the stated range ends above it.
By their numbers in this assay, from the lowest: compound 2; then compounds 4 and 3 (each within the scatter of the next); then compound 1.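

The same removal of ethyl on a saturated chain carbon that gave a 10-fold higher number from compound 2 to compound 3 (1.00 log units; beyond the scatter) now gives a 2.0-fold lower number from compound 3 to compound 4 (0.30 log units; within the scatter), so among these compounds the effect of shortening does not repeat from one stage to the next. Compound 2 stays apart, with a 5.0-fold higher number from compound 2 to compound 4 (0.70 log units; beyond the scatter), while the change at the other end of the series reads a 10-fold lower number from compound 1 to compound 4 (1.00 log units; beyond the scatter). Nothing available explains why the two shortenings differ. Still open, going by these compounds, is how a longer chain than that of compound 2, or a carboxylic acid in place of the ester, would read.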